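The compounds below may be only part of what the source reports. "The series", "measured", "known", "first", "only" and "open" are said of these compounds alone.

Measured in a functional assay on PC-3 cells (Homo sapiens) for inhibition, read by sulforhodamine B assay, with a stated time of 48 h, tested at 50 uM; on this read-out lower numbers stand for less inhibition of growth and higher numbers for more inhibition of growth at the one concentration tested:
- Compound 1 `COc1cccc(/C=C/C(=O)/C=C/c2ccc(OCc3cn(CCOc4cc(=O)oc5ccccc45)nn3)c(OC)c2)c1`: 13%
- Compound 2 `COc1ccc(/C=C/C(=O)/C=C/c2ccc(OCc3cn(CCCOc4cc(=O)oc5ccccc45)nn3)c(OC)c2)cc1OC`: 9%
- Compound 3 `COc1ccc(/C=C/C(=O)/C=C/c2ccc(OCc3cn(CCCCOc4cc(=O)oc5ccccc45)nn3)c(OC)c2)cc1`: "not active" (no number reported)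

In this assay compound 1 gives 13%, and compound 2 gives 9%, so these two numbers lie within the scatter of each other. Compound 3, reported as "not active" (no number reported), has no number to compare. Compound 4 `COc1ccc(/C=C/C(=O)/C=C/c2ccc(OCc3cn(CCOc4cc(=O)oc5ccccc45)nn3)c(OC)c2)cc1` has 4-methoxyphenyl in place of 3-methoxyphenyl on a double-bonded chain carbon bound to a double-bonded chain carbon. For the measured compounds named here, no measured pair isolates this change, so no step beyond the scatter is expected in this assay. The estimated a number 3 percentage points lower from compound 1 to compound 4 (within the scatter) is small. For compound 4 the expected value is 10%, with an expected range from 0% to 22%.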

Compound 4, percent growth inhibition at one concentration: 15%
For compound 4 the middle estimate is 5 percentage points below the measured one, and the stated range covers the measured number.
By their numbers in this assay, from the lowest: compounds 2, 1 and 4 (each within the scatter of the next).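

In this assay the swap of 3-methoxyphenyl for 4-methoxyphenyl gives a number 2 percentage points higher from compound 1 to compound 4 (within the scatter) on this double-bonded chain carbon. For the compounds shown here, this is the first single change that can be read on its own, and at this place the two methoxyphenyl groups cannot be told apart. No measurement shown offers an explanation for this result.

Going by these compounds, what an amine or a carboxylic acid on this ring would do to growth inhibition remains open. The effect of the chain length alone also remains open, as no pair shown isolates it.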